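Chloro in place of methoxy on the benzyl ring

A few compounds are considered here, and "the series" means these few. Any claim that something is new, unique, unknown or untested is made for them only; others in the source may bear on it.

The series shares one core, carried here by compound 1 `CCOC(=O)N1[C@@H]2C=C[C@@](OC)(C(=O)c3c2cc(OC)c(OC)c3OCc2ccc(OC)cc2)N1C(=O)OCC`. In an ADME assay on KB cells (Homo sapiens) for cytotoxicity (on this read-out higher numbers stand for an effect only at larger amounts of compound and lower numbers for an effect already at smaller amounts), compound 1 gives 63.1 ug/mL. Compound 2 `COC(=O)N1[C@@H]2C=C[C@@](OC)(C(=O)c3c2cc(OC)c(OC)c3OCc2ccccc2)N1C(=O)OC`, which lacks any substituent on its benzyl ring, reaches only > 300 ug/mL in this assay, a limit rather than a number. Going by the values given here, compound 3 `COC(=O)N1[C@@H]2C=C[C@@](OC)(C(=O)c3c2cc(OC)c(OC)c3OCc2ccccc2F)N1C(=O)OC` gives 137 ug/mL, and the single measured step, an at least 2.1-fold lower number from compound 2 to compound 3 (0.34 log units; beyond the scatter), shows that a small substituent on that ring moves the number downward. Of the two numbers shown, compound 1 has the lowest, and the value of compound 3 stands higher than it by a margin beyond the scatter.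

Compound 4 `CCOC(=O)N1[C@@H]2C=C[C@@](OC)(C(=O)c3c2cc(OC)c(OC)c3OCc2ccc(Cl)cc2)N1C(=O)OCC` differs from compound 1 by chloro in place of methoxy on an aromatic carbon. Among the compounds with values here, no measured pair shows chloro in place of methoxy; the only step on this ring, an at least 2.1-fold lower number from compound 2 to compound 3 (0.34 log units; beyond the scatter), concerns fluoro for hydrogen and shows that a halogen there is tolerated without a rise in the number. From that, a step of a 1.3-fold lower number from compound 1 to compound 4 (0.10 log units; within the scatter) is expected, at most a modest shift and plausibly within the scatter. Compound 4 is therefore estimated at 50 ug/mL, with a range from 20 ug/mL to 150 ug/mL.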

Compound 4, concentration for half-maximal effect: 99.9 ug/mL
Compound 4: the middle estimate sits 2.0-fold (0.30 log units) below what was measured; the measured number falls inside the stated range.
By their numbers in this assay, from the lowest: compounds 1, 4 and 3 (each within the scatter of the next, the first and the last beyond it). At a limit, above all of these: compound 2.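

Going by these compounds alone, the step, a 1.6-fold higher number from compound 1 to compound 4 (0.20 log units; within the scatter), is the first reading of one substituent exchanged for another at this place on the benzyl ring, and in this assay it stays within the scatter. On this read-out, 4-methoxybenzyl and 4-chlorobenzyl therefore cannot be told apart, even though a hydrogen-bond acceptor leaves with the methoxy and none enters with the chloro. The earlier step, fluoro in place of hydrogen, started from a compound without a number, as compound 2 stands at a limit of the assay: the limit of > 300 ug/mL in this assay, at which 1 of the 4 values shown sits.

The compounds shown leave open whether this flat result would hold for an amine, a carboxylic acid or a nitrile at the same place on the ring, or for a plain benzyl group alongside the ethyl ester groups of compound 1 and compound 4. Nor can the ethyl and methyl ester groups on the shared core be weighed against each other from the pairs shown, so their part in the numbers remains unknown.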